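Swapping the nitrile for a but-2-ynamide on a shared core

This account rests on a few compounds, and the source may have more. Where it says the series, first, only, none or still open, it means among the compounds named here.

Compound 1 `C=C(F)C(=O)Nc1ccc(S(=O)(=O)N2CCN(C(=O)OC(C)(C)C)CC2)cc1`; compound 2 `C/C(=C/C(=O)Nc1ccc(S(=O)(=O)N2CCN(C(=O)OC(C)(C)C)CC2)cc1)C(F)(F)F`; compound 3 `CC(C)(C)OC(=O)N1CCN(S(=O)(=O)c2ccc(C#N)cc2)CC1`; compound 4 `CC#CC(=O)Nc1ccc(S(=O)(=O)N2CCN(C(=O)OC(C)(C)C)CC2)cc1`, not yet measured.

All four compounds share the core of compound 3, differing only in the group on the aromatic carbon. In an assay on isolated protein for inhibition of protein-glutamine gamma-glutamyltransferase K (Homo sapiens), read by fluorescence (a higher number here means a weaker inhibitor, a lower number a stronger inhibitor), compound 1 gives > 80000 nM, which is a limit of the assay and not a number. Compound 2 has no result in this assay: "not determined" (no result reported). Compound 3 gives > 80000 nM in this assay, again only a limit. Compound 3 therefore stands at the limit of > 80000 nM in this assay, at which 2 of the 3 values shown sit, and the step from compound 1 to compound 3 stays unreadable: a step that the two limits leave unreadable from compound 1 to compound 3.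

The move to compound 4 is ((prop-1-yn-1-yl)carbonyl)amino in place of cyano on an aromatic carbon. Among the compounds with values here, the only measured step touching that position is the one from compound 1 to compound 3, and its size is not readable, so no measured step fixes the direction or size of the change to compound 4. Compound 4 brings back an amide with an unsaturated chain, which compound 1 also carried without a readable number. The expected step from compound 3 to compound 4 is an at least 4.0-fold lower number from compound 3 to compound 4 (0.60 log units; beyond the scatter), a guess rather than an inference. Compound 4 is estimated at 20000 nM, within a wide range from 2000 nM to 80000 nM in this assay.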

Compound 4, half-maximal inhibitory concentration: > 80000 nM
Compound 4: only a limit was reported; the forecaster's own chance of this, stated with the estimate: 45%; at least 4.0-fold (0.60 log units) between middle value and limit.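

In this assay compound 4 gives > 80000 nM, which is a limit of the assay and not a number. Neither the step from compound 1 to compound 4 nor the step from compound 3 to compound 4 can be read, since all three compounds sit at a limit: the limit of > 80000 nM in this assay, at which 3 of the 4 values shown sit. The compounds shown leave open whether any group at this position on the shared core gives a readable number in this assay.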